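A few compounds are considered here, and "the series" means these few. Any claim that something is new, unique, unknown or untested is made for them only; others in the source may bear on it.

Two compounds share a core in which a benzoate ester and a difluorophenyl group sit on the same aromatic ring, and differ only in what hangs on a carbonyl carbon. Compound 1 `O=C(Oc1ccc(-c2ccc(F)cc2F)cc1C(=O)O)c1ccccc1` carries a hydroxy there; in a functional assay on the whole organism (strain Kunming) for inhibition, with Mus musculus as the target, in the writhing test, at a dose of 40 mg/kg by the oral route (a lower number here means less inhibition, a higher number more inhibition at the dose given (going by the name of the read-out)), compound 1 gives 7.97%. Compound 2 `O=C(Oc1ccc(-c2ccc(F)cc2F)cc1C(=O)Nc1ccccc1)c1ccccc1` carries an anilino instead; in this assay compound 2 gives 5.57%. The step of a number 2.4 percentage points lower from compound 1 to compound 2 (within the scatter) lies within the scatter, so the two numbers cannot be told apart, and compound 2 stands on a par with compound 1 with no order between them.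

Compound 3 `CCN(CC)C(=O)c1cc(-c2ccc(F)cc2F)ccc1OC(=O)c1ccccc1` is not yet measured. It differs from compound 2 in one place: diethylamino in place of anilino on a carbonyl carbon. Going by the values given here, the only step that bears on this one is the change at the same carbonyl carbon, a number 2.4 percentage points lower from compound 1 to compound 2 (within the scatter), which stayed within the scatter. With nothing else to go on, a further exchange at that carbonyl carbon is expected to move the number no further than the scatter, giving an estimated step of a number 1.4 percentage points higher from compound 2 to compound 3 (within the scatter). Compound 3 is therefore estimated at 7%, with a range from 0% to 18%.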

Compound 3, a percentage reported as inhibition, in the whole organism at one dose (the size of the read-out at that dose, not a potency): 0%
For compound 3 the middle estimate is 7 percentage points above the measured one; the range from low to high includes it.
By their numbers in this assay, from the lowest: compounds 3, 2 and 1 (each within the scatter of the next).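

At this carbonyl carbon the series now holds a hydroxy, a ring-bearing anilino and an open-chain diethylamino. In this assay the exchange of anilino for diethylamino gives a number 5.6 percentage points lower from compound 2 to compound 3 (within the scatter) and the exchange of hydroxy for diethylamino gives a number 8 percentage points lower from compound 1 to compound 3 (within the scatter) in the same read-out. So losing the aromatic ring and the amide hydrogen of the anilino does not separate compound 3 from compound 2, and all three groups tried at this place remain indistinguishable at this single dose. Nothing available here explains these numbers or says what limits them.

As far as these compounds go, what a morpholine ring or a plain amino group would give on this carbonyl carbon remains open, since three groups cannot show whether any exchange here can move the number beyond the usual scatter. Also open, from the compounds shown here alone, is whether a change elsewhere on the shared core, such as an acetyl in place of the benzoyl of the ester, would give a clearer signal than exchanges at this carbonyl carbon have so far.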